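Chloro to Dimethylamino: Expected Potency of Compound 4

The compounds below may be only part of what the source reports. "The series", "measured", "known", "first", "only" and "open" are said of these compounds alone.

Three compounds share one core. Compound 1 `CC(=O)N1N=C(c2ccccc2)CC1c1ccc(N(C)C)cc1` gives 14600 nM in a functional assay on HEp-2 cells (Homo sapiens) for cytotoxicity, read by sulforhodamine B assay, with a stated time of 48 h; on this read-out lower numbers stand for stronger inhibition and higher numbers for weaker inhibition. Compound 2 `CC(=O)N1N=C(c2ccco2)CC1c1ccc([N+](=O)[O-])cc1` gives 21800 nM in this assay, and compound 3 `CC(=O)N1N=C(c2ccco2)CC1c1ccc(Cl)cc1` gives 57400 nM, the highest of the three numbers. Among the compounds with values here, the only single-site step measured, a 2.6-fold higher number from compound 2 to compound 3 (0.42 log units; beyond the scatter), shows that exchanging the group on an aromatic carbon moves the number beyond the scatter. Compound 4 `CC(=O)N1N=C(c2ccco2)CC1c1ccc(N(C)C)cc1` differs from compound 3 by dimethylamino in place of chloro on an aromatic carbon. Within the data shown here, no measured step covers this exchange directly; compound 1, which carries the same dimethylamino group, gives 14600 nM, the lowest number of the set. On that basis a downward step is expected for a 2.9-fold lower number from compound 3 to compound 4 (0.46 log units; beyond the scatter). Compound 4 is estimated at 20000 nM, within 8000 nM to 50000 nM.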

Compound 4, half-maximal inhibitory concentration: 16000 nM
The estimate for compound 4 lay 1.3-fold (0.10 log units) above the measured number, and the stated range covers the measured number.
By their numbers in this assay, from the lowest: compounds 1, 4 and 2 (each within the scatter of the next); then compound 3.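

In this assay dimethylamino in place of chloro gives a 3.6-fold lower number from compound 3 to compound 4 (0.55 log units; beyond the scatter) and so moves the number beyond the scatter at this aromatic carbon. Dimethylamino in place of nitro at the same place gives a 1.4-fold lower number from compound 2 to compound 4 (0.13 log units; within the scatter) and stays within the scatter. With dimethylamino held, furan-2-yl in place of phenyl gives a 1.1-fold higher number from compound 1 to compound 4 (0.04 log units; within the scatter) and also stays within the scatter.

The compounds shown leave open how a primary amine or a carboxylic acid on this aromatic carbon would read in this assay and nothing here bears on why. No supporting evidence accounts for these steps.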